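Amino in Place of Chloro: Expected Cytotoxicity of Compound 4

The source may hold more compounds than are shown below. What is called first, only, known or untested is meant among the compounds shown, and "the series" means these compounds.

Of the compounds shown here, three have been tested in a functional assay on SF-268 cells (Homo sapiens) for cytotoxicity, read by sulforhodamine B assay, with a stated time of 48 h; on this read-out lower numbers stand for higher toxicity in this test and higher numbers for lower toxicity in this test. Compound 1 `Nc1nc(Cl)c2ncn(Cc3ccc(CCl)cc3)c2n1` gives 38900 nM, compound 2 `ClCc1cccc(Cn2cnc3c(Cl)nc(Cl)nc32)c1` gives 70800 nM, and compound 3 `ClCc1ccc(Cn2cnc3c(Cl)nc(Cl)nc32)cc1` gives 42700 nM; all three lie within the scatter of one another. Compound 3 and compound 1 differ by one change, (amino in place of chloro on an aromatic carbon), and that change made a 1.1-fold lower number from compound 3 to compound 1 (0.04 log units; within the scatter). Compound 2 and compound 3 have the same atoms joined differently; the difference between the two cores is not broken down here. Compound 4 `Nc1nc(Cl)c2ncn(Cc3cccc(CCl)c3)c2n1` has not been measured. It arises from compound 2 by the same change, (amino in place of chloro on an aromatic carbon). Because the earlier step of a 1.1-fold lower number from compound 3 to compound 1 (0.04 log units; within the scatter) stayed within the scatter, a similarly small step is expected for compound 4, namely a 1.1-fold lower number from compound 2 to compound 4 (0.04 log units; within the scatter). Compound 4 is therefore estimated at 64000 nM, expected to fall between 30000 nM and 140000 nM.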

Compound 4, concentration lethal to 50% of the cells: 67600 nM
Beside the measured number, compound 4's estimate is 1.1-fold (0.02 log units) below it; measured number inside the range.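

In this assay, amino in place of chloro on an aromatic carbon gives a 1.0-fold lower number from compound 2 to compound 4 (0.02 log units; within the scatter), so on this core too the step stays within the scatter. Set side by side, the two steps agree: the same change on two cores in this assay, a 1.1-fold lower number (0.04 log units; within the scatter) from compound 3 to compound 1 and a 1.0-fold lower number (0.02 log units; within the scatter) from compound 2 to compound 4, 1.0-fold (0.02 log units) apart, within the scatter of two such steps. This shows that the change carried over between these two closely related cores, which have the same atoms joined differently, but it does not show that it would carry to any other core, and it says nothing about why the step is so small.

The compounds shown leave open whether another group in that place, such as a methoxy group or a methylamino group, would also stay within the scatter. They also leave open what replacing the chloromethyl group, for instance with a plain methyl group, would do.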